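The source may hold more compounds than are shown below. What is called first, only, known or untested is meant among the compounds shown, and "the series" means these compounds.

Of the compounds shown here, three have been measured so far in a functional assay on HCT-116 cells (Homo sapiens) for inhibition, read by CCK-8 assay, with a stated time of 72 h, tested at 8 uM; on this read-out higher numbers stand for more inhibition of growth at the one concentration tested and lower numbers for less inhibition of growth. Compound 1 `Nc1ccccc1NC(=O)/C=C/c1ccc(CSc2ccc(Cl)cc2)cc1` gives 3.27% and compound 2 `Nc1ccccc1NC(=O)/C=C/c1ccc(CSc2cccc(F)c2)cc1` gives 3.22%, so these two sit together at the low end of the numbers. Compound 3 `CCc1ccc(SCc2ccc(C(=O)Nc3ccccc3N)cc2)cc1` gives 79.1%, a far larger number than either of them, but it differs from them in more than one place, so it cannot show what any single change does.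

Compound 4 `Cc1ccc(SCc2ccc(/C=C/C(=O)Nc3ccccc3N)cc2)cc1` departs from compound 2 in one place only, with 4-methylphenyl in place of 3-fluorophenyl on a sulfur.

Among the measured compounds shown here, one measured step bears on this change. It also swaps one substituted phenyl group on that sulfur for another, with 3-fluorophenyl in place of 4-chlorophenyl, and it gave a number 0.1 percentage points lower from compound 1 to compound 2 (within the scatter). On that evidence, no step beyond the scatter is expected in this assay, and a number 2.8 percentage points higher from compound 2 to compound 4 (within the scatter) is the expected step. A single step is thin evidence, however, and compound 3 at 79.1% shows that this read-out can run far higher, so the expected range is left wider on the upper side. For compound 4 the estimated value is 6%, with an expected range from 0% to 25%.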

Compound 4, percent growth inhibition at one concentration: 4.93%
Estimate against measurement, compound 4: 1.1 percentage points above; low and high end bracket the measured number.
By their numbers in this assay, from the lowest: compounds 2, 1 and 4 (each within the scatter of the next); then compound 3.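

Within this assay, putting 4-methylphenyl in place of 3-fluorophenyl on the sulfur gives a number 1.7 percentage points higher from compound 2 to compound 4 (within the scatter) and so the phenyl group on this sulfur can lose its fluorine and gain a methyl without a step beyond the scatter. Methyl in place of chloro on an aromatic carbon gives a number 1.7 percentage points higher from compound 1 to compound 4 (within the scatter) and this extends the picture: chloro, fluoro and methyl versions of the phenyl group now all sit together at the low end, where the earlier pair offered only two groups that each carry a halogen. No measurement at hand offers any reason why these three groups read alike.

As far as these compounds go, whether an amine or a carboxylic acid on that phenyl ring, or a longer chain in place of the ring, would lift the number out of this low band remains open. Compound 3 at 79.1% stands far from these three, but it differs from them in more than one place, so which of its differences matters cannot be read.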